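Methoxy build-up on the aryl ring: cytotoxicity series

The source may report more compounds than this note shows. Statements on the series, on what has been measured and on what is new or still open speak of the compounds shown alone.

Of the compounds shown here, three carry numbers so far in a functional assay on HPLF cells (Homo sapiens) for cytotoxicity; a lower number here means that less compound is tolerated, a higher number that more compound is tolerated. Compound 1 `COc1cc(/C=C2\Cc3ccccc3/C(=C\c3ccc([N+](=O)[O-])cc3)C2=O)ccc1O` gives 21000 nM. Compound 2 `COc1cc(/C=C2\CCC/C(=C\c3ccc([N+](=O)[O-])cc3)C2=O)ccc1O` gives 171000 nM. Compound 3 `COc1ccc(/C=C2\CCC/C(=C\c3ccc([N+](=O)[O-])cc3)C2=O)cc1OC` gives 95000 nM, the second highest of the three; compound 2 lies nearest to it, and compound 1 shows a lower number, beyond the scatter. Going by the values given here, the one step between compounds differing in a single place, a 1.8-fold lower number from compound 2 to compound 3 (0.26 log units; within the scatter), turns one hydroxyl of the aromatic ring into a methoxy.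

Compound 4 `COc1cc(/C=C2\CCC/C(=C\c3ccc([N+](=O)[O-])cc3)C2=O)cc(OC)c1OC` is not yet measured. It differs from compound 3 by methoxy in place of hydrogen on an aromatic carbon. Among the compounds with values here, the only step that bears on this change is the small substitution from compound 2 to compound 3 on the same ring, which stayed within the scatter; a further small group there is therefore expected to give no step beyond the scatter in this assay . The expected step is no change at the digits printed from compound 3 to compound 4 (within the scatter). Compound 4 is estimated at 95000 nM, in the range 40000 nM to 220000 nM.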

Compound 4, half-maximal cytotoxic concentration: 378000 nM
Compound 4: the middle estimate sits 4.0-fold (0.60 log units) below what was measured, outside the stated range (above it).
By their numbers in this assay, from the lowest: compound 1; then compounds 3 and 2 (each within the scatter of the next); then compound 4.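

On this ring, methoxy in place of hydrogen on an aromatic carbon, ortho to a methoxy group, does register in this assay: the result is a 4.0-fold higher number from compound 3 to compound 4 (0.60 log units; beyond the scatter). The earlier change on the same ring, a 1.8-fold lower number from compound 2 to compound 3 (0.26 log units; within the scatter), stayed within the scatter, so this position responds to an added methoxy in a way that step did not reveal, with more compound tolerated. No measurement of any property of these compounds bears on this step, and the data give no reason for it.

Going by these compounds, whether the step belongs to methoxy itself remains open, as no other group, such as an ethoxy, an amine or a fluorine atom, appears at this position. Also open, on these data alone, is whether the same addition would move the number on the core of compound 1.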